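From Methyl to Chloro on the Aromatic Ring

This account rests on a few compounds, and the source may have more. Where it says the series, first, only, none or still open, it means among the compounds named here.

Of the compounds shown here, three built on a shared core have numbers so far in a functional assay on the whole organism for antagonist activity, with Mus musculus as the target, in the maximal electroshock model (on this read-out lower numbers stand for an effect already at smaller amounts and higher numbers for an effect only at larger amounts of compound), and these set the frame. There compound 1 `COC(=O)NC1=NC(c2cccc(Cl)c2)CN1` gives 48 mg/kg while compound 2 `COC(=O)NC1=NC(c2ccccc2)CN1C` gives 107 mg/kg and compound 3 `COC(=O)NC1=NC(c2cccc(C)c2)CN1C` gives 89 mg/kg as its dose. Compound 3 stands within the usual scatter of both compound 2 and compound 1, so its place among the three carries little weight.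

The next compound, compound 4 `COC(=O)NC1=NC(c2cccc(Cl)c2)CN1C`, has no number yet. It differs from compound 3 as follows: chloro in place of methyl on an aromatic carbon with chloro in place of methyl on an aromatic carbon, meta to a large group.

Going by the values given here, only one measured step bears on this place: a 1.2-fold lower number from compound 2 to compound 3 (0.08 log units; within the scatter) for methyl in place of hydrogen on an aromatic carbon. Among the compounds with values here, no measured step puts chloro in place of methyl, so the guidance is indirect. Within the data shown here, compound 1 at 48 mg/kg is the only chloro compound with a number, and it lies within the scatter of compound 3.

No shift beyond the scatter is therefore expected in this assay, at most a slight drift towards lower numbers. The expected change is a 1.3-fold lower number from compound 3 to compound 4 (0.10 log units; within the scatter) in this estimate. For compound 4 the estimated value is 70 mg/kg with an expected range from 38 mg/kg to 125 mg/kg on measurement.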

Compound 4, dose for half-maximal effect: 100 mg/kg
Beside the measured number, compound 4's estimate is 1.4-fold (0.15 log units) below it; the measured number falls inside the stated range.
By their numbers in this assay, from the lowest: compounds 1, 3, 4 and 2 (each within the scatter of the next, the first and the last beyond it).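

In this assay, chloro in place of methyl on an aromatic carbon, meta to a large group, gives a 1.1-fold higher number from compound 3 to compound 4 (0.05 log units; within the scatter), while chloro in place of hydrogen at that place gives a 1.1-fold lower number from compound 2 to compound 4 (0.03 log units; within the scatter), so with a 1.2-fold lower number from compound 2 to compound 3 (0.08 log units; within the scatter) already known, hydrogen, methyl and chloro there are not told apart by this read-out. The only step beyond the scatter among these new ones lies elsewhere on the molecule: methyl in place of hydrogen on an amine nitrogen in a ring gives a 2.1-fold higher number from compound 1 to compound 4 (0.32 log units; beyond the scatter), a modest change, and the chloro group stays the same across that pair. Nothing measured here offers an explanation for either the flat aromatic position or the shift at the nitrogen.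

Whether the nitrogen step keeps its size with hydrogen or methyl on the aromatic carbon stays open, as the compounds shown offer that comparison only with chloro present. As far as these compounds go, how a methoxy group or a nitrile would read at the aromatic position, or an ethyl group on the ring nitrogen, also remains unknown from these compounds.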